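The source may report more compounds than this note shows. Statements on the series, on what has been measured and on what is new or still open speak of the compounds shown alone.

Measured so far:
- compound 1 `CCCCCCCCCCCCCCCCCCOP(=O)(O)OC[C@H]1O[C@@H](n2ccc3c(-c4ccco4)ncnc32)[C@H](O)[C@@H]1O`: > 50000 nM, a limit
- compound 2 `CCCCCCCCCCCCCCCCCCOP(=O)(O)OC[C@H]1O[C@@H](n2ccc3c(-c4ccoc4)ncnc32)[C@H](O)[C@@H]1O`: 44200 nM

Going by the values given here, in an ADME assay on BJ cells (Homo sapiens) for cytotoxicity, read by MTT assay, with a stated time of 72 h (a higher number here means that more compound is tolerated, a lower number that less compound is tolerated), compound 2 gives 44200 nM, the only actual number so far. Compound 1 gives > 50000 nM, which is a limit. Compound 3 `CCCCCCCCCCCCCCCCCCOP(=O)(O)OC[C@H]1O[C@@H](n2ccc3c(-c4cc5ccccc5o4)ncnc32)[C@H](O)[C@@H]1O` brings the change 1-benzofuran-2-yl in place of furan-3-yl on an aromatic carbon: 1-benzofuran-2-yl in place of furan-3-yl. Among the compounds with values here, the one measured step bearing on this is an at least 1.1-fold lower number from compound 1 to compound 2 (0.05 log units; that floor lies within the scatter). It swaps one furan for another and does not cover the added six-membered ring, so it is weak support. No step beyond the scatter is therefore expected, and the direction stays uncertain. The expected move is a 1.5-fold lower number from compound 2 to compound 3 (0.17 log units; within the scatter). For compound 3 the estimate is 30000 nM, with an expected range of 12000 nM to 50000 nM.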

Compound 3, half-maximal cytotoxic concentration: > 50000 nM
Compound 3 was reported as a limit; the forecaster's own chance of this, stated with the estimate: 30%; at least 1.6-fold (0.22 log units) between middle value and limit.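

In this assay, 1-benzofuran-2-yl in place of furan-3-yl on this aromatic carbon gives an at least 1.1-fold higher number from compound 2 to compound 3 (0.05 log units; that floor lies within the scatter), so the added six-membered aromatic ring of carbon only produces no step beyond the scatter. The step between compound 1 and compound 3 cannot be read. Most of the series sits at one limit: the limit of > 50000 nM in this assay, at which 2 of the 3 values shown sit.

Going by these compounds, it remains open whether an amine or a carboxylic acid on this aromatic carbon, in place of the furan and benzofuran groups, would give a measured number clearly under that limit.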